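The source may hold more compounds than are shown below. What is called first, only, known or untested is meant among the compounds shown, and "the series" means these compounds.

Compound 1 `CCCCCCCCc1ccc(CCC(CO)(CO)NC(=O)CCCCCCC)c2ccccc12` gives 22000 nM in a functional assay on HT-29 cells (Homo sapiens) for antiproliferative activity, read by sulforhodamine B assay, with a stated time of 72 h; a higher number here means a weaker inhibitor, a lower number a stronger inhibitor. Compound 2 `CCCCCCCCCCCCCC(=O)NC(CO)(CO)CCc1ccc(CCCCCCCC)c2ccccc12` returns only a limit in this assay, > 80000 nM. The change between them, (hexyl in place of hydrogen on a saturated chain carbon, seven bonds along the chain from a carbonyl carbon), makes a step of an at least 3.6-fold higher number from compound 1 to compound 2 (0.56 log units; beyond the scatter). Compound 3 `COc1ccc(CCC(CO)(CO)NC(C)=O)c2ccccc12` also reaches only a limit in this assay, > 80000 nM. The difference between the core of compound 3 and the core of compound 1 is not broken down here. Compound 4 `CCCCCCCOc1ccc(CCC(CO)(CO)NC(C)=O)c2ccccc12` carries the change (hexyl in place of hydrogen on a saturated chain carbon bound to an oxygen on an aromatic ring); this is the same kind of change as from compound 1 to compound 2, but the place differs: there on a saturated chain carbon, seven bonds along the chain from a carbonyl carbon, here on a saturated chain carbon bound to an oxygen on an aromatic ring. Given (the limit of > 80000 nM in this assay, at which 2 of the 3 values shown sit), where compound 3 already sits, and the weakening seen in an at least 3.6-fold higher number from compound 1 to compound 2 (0.56 log units; beyond the scatter), the step from compound 3 to compound 4 is expected to be about a step that the limit leaves unreadable from compound 3 to compound 4. Compound 4 is estimated at 120000 nM, most likely once more only a limit in this assay.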

Compound 4, half-maximal inhibitory concentration: 17600 nM
The estimate for compound 4 lay 6.8-fold (0.83 log units) above the measured number; the measured number lies below the stated range.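

Hexyl in place of hydrogen, here methoxy to heptyloxy, gives an at least 4.5-fold lower number from compound 3 to compound 4 (0.65 log units; beyond the scatter). The same kind of change does not carry over in sign or size from the earlier place to this one: the same change on two cores in this assay, an at least 3.6-fold higher number (0.56 log units; beyond the scatter) from compound 1 to compound 2 and an at least 4.5-fold lower number (0.65 log units; beyond the scatter) from compound 3 to compound 4, at least 16-fold (1.21 log units) apart, beyond the scatter of two such steps The change sits in a different place on each core, and each step has a limit at one end, so the pair neither separates place from core nor gives either step an exact size: the limit of > 80000 nM in this assay, at which 2 of the 4 values shown sit.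

Still open, going by these compounds, is whether a chain longer than heptyloxy lowers the number further in this assay. Also open, on these data alone, is what an amine or a carboxylic acid in place of the hexyl would do.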